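Replacing pyridin-3-yl with 2-hydroxyphenyl at the carbonyl

The source may report more compounds than this note shows. Statements on the series, on what has been measured and on what is new or still open speak of the compounds shown alone.

Compound 1 `O=C(/C=C/c1ccc2c(c1)B(O)OC2)c1cccnc1` gives 76200 nM
Compound 2 `O=C(/C=C/c1ccc2c(c1)B(O)OC2)c1ccc(C(F)(F)F)cc1` gives 22600 nM

Both readings come from a toxicity assay on WI-38 cells (Homo sapiens) for cytotoxicity, read by MTT assay, with a stated time of 48 h; a lower number here means a stronger inhibitor, a higher number a weaker inhibitor. Compound 1 stands at the higher of the two numbers, and compound 2 sits clearly lower, a gap beyond the usual scatter. Compound 3 `O=C(/C=C/c1ccc2c(c1)B(O)OC2)c1ccccc1O` has not yet been measured; it differs from compound 1 in a single place: 2-hydroxyphenyl in place of pyridin-3-yl on a carbonyl carbon. Among the measured compounds shown here, no measured pair shows this same change, so the expected step is small, if anything toward a lower number, and not clearly beyond the scatter: a 1.7-fold lower number from compound 1 to compound 3 (0.23 log units; within the scatter). Compound 3 is therefore estimated at 45000 nM, with a likely range from 15000 nM to 120000 nM.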

Compound 3, half-maximal inhibitory concentration: > 100000 nM
Compound 3: only a limit was reported (the forecaster's own chance of this, stated with the estimate: 10%); at least 2.2-fold (0.34 log units) between middle value and limit.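

In this assay the reading for compound 3 is a limit and not a number: the limit of > 100000 nM in this assay, at which 1 of the 3 values shown sits. Putting 2-hydroxyphenyl in place of pyridin-3-yl on a carbonyl carbon gives an at least 1.3-fold higher number from compound 1 to compound 3 (0.11 log units; that floor lies within the scatter) and so no sign of a drop in the number, yet that floor alone does not separate the two compounds.

On these data alone, how far compound 3 truly lies past its limit stays open, and with it the real size of this step. Also open, as far as these compounds go, is what a 2-aminophenyl group would give on the same carbonyl carbon.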